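A few compounds are considered here, and "the series" means these few. Any claim that something is new, unique, unknown or untested is made for them only; others in the source may bear on it.

Three acylhydrazones on a shared core have been measured in a functional assay on BGC-823 cells (Homo sapiens) for inhibition, read by sulforhodamine B assay, with a stated time of 48 h, tested at 10 uM; a higher number here means more inhibition of growth at the concentration tested, a lower number less inhibition of growth. Compound 1 `O=C(N/N=C/c1ccccc1)c1ccc(-c2ccc(Cl)cc2)o1` gives 33.7%. Compound 2 `O=C(N/N=C/c1ccc(O)cc1)c1ccc(-c2ccc(F)cc2)o1` gives 46.3%. Compound 3 `COc1ccccc1C(=O)N/N=C/c1ccc(-c2ccc(F)cc2F)o1` gives 35.9%. On these three numbers compound 2 stands highest: the nearest is compound 3, lower by a margin beyond the scatter, and the furthest is compound 1, lower by a larger margin, also beyond the scatter. With three compounds that differ in more than one place, no single change can be read from the numbers as yet.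

Compound 4 `O=C(N/N=C/c1ccccc1Cl)c1ccc(-c2ccc(F)cc2)o1` is the next to be measured in this assay. It keeps the core and the fluorophenyl group of compound 2 and differs from it at one place: 2-chlorophenyl in place of 4-hydroxyphenyl on a carbon with a double bond to nitrogen. The change removes a hydrogen-bond donor and acceptor on the ring attached to the carbon with a double bond to nitrogen. For the measured compounds named here, no measured pair here isolates this change, so the direction is not fixed by the data; compound 1, which carries an unsubstituted phenyl at that place, sits well below compound 2, which argues for a modest loss. The expected step from compound 2 to compound 4 is therefore a small drop, a number 8.3 percentage points lower from compound 2 to compound 4 (within the scatter), close to the edge of the scatter. Compound 4 is expected to give 38% in this assay, with a range from 24% to 52%.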

Compound 4, percent growth inhibition at one concentration: 32%
Estimate against measurement, compound 4: 6 percentage points above, within the range that was stated.
By their numbers in this assay, from the lowest: compounds 4, 1 and 3 (each within the scatter of the next); then compound 2.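

In this assay the series gains its first step read at one place, a number 14.3 percentage points lower from compound 2 to compound 4 (beyond the scatter) with 2-chlorophenyl in place of 4-hydroxyphenyl on a carbon with a double bond to nitrogen. The shared core and the fluorophenyl group stay the same across this pair, so the ring at this place is shown to matter for growth inhibition at the concentration tested, and the 4-hydroxyphenyl ring is the better of the two rings compared here. Nothing measured bears on why the step occurs, and the removal of the hydroxyl cannot be separated from the arrival of the chlorine.

Still open, from the compounds shown here alone, is whether an amine, a carboxylic acid or a methoxy group on this ring would hold the number near that of compound 2 at 46.3% or would fall away as the 2-chlorophenyl ring does. Also open, going by these compounds, is whether a step of this size would recur with a group other than fluorophenyl on the far side of the core, such as a longer alkyl chain, since this single pair speaks only for the fluorophenyl series.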